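Carbonyl to sulfonyl on the ring amine nitrogen

A few compounds are considered here, and "the series" means these few. Any claim that something is new, unique, unknown or untested is made for them only; others in the source may bear on it.

Measured compounds:
compound 1 `O=C(c1ccc(Cl)cc1)N1CCC(NS(=O)(=O)c2cc(S(=O)(=O)c3ccccc3)ccc2C(F)(F)F)CC1` — in an assay on isolated protein for displacement of a labelled ligand from secreted frizzled-related protein 1 (Homo sapiens), read by fluorescence polarization, with a stated time of 30 min (a higher number here means a weaker inhibitor, a lower number a stronger inhibitor), compound 1 gives 300 nM
compound 2 `O=C(c1ccc(C(F)(F)F)cc1)N1CCC(NS(=O)(=O)c2cc(S(=O)(=O)c3ccccc3)ccc2C(F)(F)F)CC1` — in this assay compound 2 gives 400 nM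
compound 3 `CN(C)c1ccc(C(=O)N2CCC(NS(=O)(=O)c3cc(S(=O)(=O)c4ccccc4)ccc3C(F)(F)F)CC2)cc1` — in this assay compound 3 gives 300 nM

Compound 2 carries the highest number of the three, but every step to the others is within the scatter: a 1.3-fold higher number from compound 1 to compound 2 (0.12 log units; within the scatter), a 1.3-fold lower number from compound 2 to compound 3 (0.12 log units; within the scatter), and also no change at the digits printed from compound 1 to compound 3 (within the scatter). Across these three compounds the substituent on the aryl ring of the amide was varied without any effect beyond the scatter in this assay.

Compound 4 `O=S(=O)(NC1CCN(S(=O)(=O)c2ccccc2)CC1)c1cc(S(=O)(=O)c2ccccc2)ccc1C(F)(F)F` differs from compound 2 in one place: phenylsulfonyl in place of (4-(trifluoromethyl)phenyl)carbonyl on an amine nitrogen in a ring. Within the data shown here, none of the measured steps touches this bond between the ring nitrogen and the aryl group; they only exchange substituents on that aryl ring, each within the scatter. So no measured step bears directly on the change, and the only guide is that this end of the molecule has so far tolerated variation without movement in this assay. For compound 4 the expected step is therefore a 1.1-fold higher number from compound 2 to compound 4 (0.05 log units; within the scatter), with wide uncertainty. Compound 4 is estimated at 450 nM, within a range from 150 nM to 1500 nM.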

Compound 4, half-maximal inhibitory concentration: 130 nM
Compound 4: the middle estimate sits 3.5-fold (0.54 log units) above what was measured, outside the stated range (below it).
By their numbers in this assay, from the lowest: compound 4; then compounds 1, 3 and 2 (each within the scatter of the next).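

In this assay the change on the ring amine nitrogen moves the number beyond the scatter, which no substituent exchange on the amide aryl ring did: the steps are a 3.1-fold lower number from compound 2 to compound 4 (0.49 log units; beyond the scatter) and a 2.3-fold lower number from compound 1 to compound 4 (0.36 log units; beyond the scatter) and a 2.3-fold lower number from compound 3 to compound 4 (0.36 log units; beyond the scatter) in the same direction. All three amides stand on the same side of compound 4, so at this position replacing the carbonyl-linked aryl group with phenylsulfonyl counts for more than the substituent on that aryl ring. Nothing available explains the lower number.

Compound 4 differs from the amides both in the linking group and in having no substituent on its aryl ring, and these compounds do not separate the two: unsubstituted phenylcarbonyl and (4-chlorophenyl)sulfonyl on this nitrogen would. Also open, going by these compounds, is how a benzyl group or a urea on this nitrogen compares.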